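The compounds below may be only part of what the source reports. "The series", "measured", "known", "first", "only" and "open" are said of these compounds alone.

Compound 1 `CN1CCN(CC(=O)NC2(c3ccc(Cl)cc3)C(=O)Nc3cc(Cl)c(Cl)cc32)CC1`: in an in vitro functional assay on CHO-CREluc cells for antagonist activity at growth hormone secretagogue receptor type 1 (Homo sapiens), read by a luciferase reporter, with a stated time of 4 h (a lower number here means a stronger inhibitor, a higher number a weaker inhibitor), compound 1 gives > 10000 nM, which is a limit of the assay and not a number.
Compound 2 `CCN1CCN(CC(=O)NC2(c3ccc(Cl)cc3)C(=O)Nc3cc(Cl)c(Cl)cc32)CC1`: in this assay compound 2 gives 110 nM.
Compound 3 `COc1ccc(C2(NC(=O)CN3CCN(C)CC3)C(=O)Nc3cc(Cl)c(Cl)cc32)cc1`: in this assay compound 3 gives 700 nM.

For the measured compounds named here, compound 1 therefore stands at the limit of > 10000 nM in this assay, at which 1 of the 3 values shown sits, the one compound of the three for which no number was obtained. Compound 4 `CN1CCN(CC(=O)NC2(c3ccc(Cl)cc3)C(=O)Nc3cc(Cl)ccc32)CC1` differs from compound 1 in a single place: hydrogen in place of chloro on an aromatic carbon. Going by the values given here, no measured pair makes this particular change, so it has to be judged indirectly. Both measured steps start from compound 1 and alter a different part of the molecule: an at least 90-fold lower number from compound 1 to compound 2 (1.95 log units; beyond the scatter) and an at least 14-fold lower number from compound 1 to compound 3 (1.15 log units; beyond the scatter). Each of these changes turned the limit into a measurable number, and each was large. On these data alone, whether removing a chloro from the fused ring does the same is untested, and the two measured changes give no direct guide to it. Because compound 1 sits at the limit of > 10000 nM in this assay, at which 1 of the 3 values shown sits, a number for compound 4 can only be expected at or below that limit, with wide uncertainty. Compound 4 is estimated to give 5000 nM in this assay, within a range of 500 nM to 30000 nM. That estimate means an expected step of an at least 2.0-fold lower number from compound 1 to compound 4 (0.30 log units; that floor lies within the scatter), with a fair chance that compound 4 also returns only a limit.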

Compound 4, half-maximal inhibitory concentration: 140 nM
Compound 4: the middle estimate sits 36-fold (1.55 log units) above what was measured, and the stated range ends above it.
By their numbers in this assay, from the lowest: compounds 2 and 4 (each within the scatter of the next); then compound 3. At a limit, above all of these: compound 1.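

In this assay, replacing one chloro with hydrogen on an aromatic carbon of the six-membered aromatic ring, ortho to a chloro group, gives an at least 71-fold lower number from compound 1 to compound 4 (1.85 log units; beyond the scatter). The earlier compounds showed large steps from changes elsewhere in the molecule, and this result adds a third place where one change from compound 1 yields a measurable number, with no compound shown going against that. The full size of this step remains unknown because compound 1 rests on a limit and not on a number: the limit of > 10000 nM in this assay, at which 1 of the 4 values shown sits.

The compounds shown have only chloro and hydrogen at this position, so they leave open whether a smaller halogen such as fluoro, a larger one such as bromo, or a nitrile would behave like the hydrogen of compound 4 or the chloro of compound 1. For the compounds shown here, they also leave open whether removing this chloro would have a similar effect when combined with the change that leads to compound 2 or the one that leads to compound 3, and what replacing the remaining chloro on that ring would do.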